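From methyl to methylsulfonyl: compound 3 and compound 4

This account rests on a few compounds, and the source may have more. Where it says the series, first, only, none or still open, it means among the compounds named here.

Three related compounds have been measured in an ADME assay on MDCKII-LE cells (Canis lupus familiaris) for permeability (on this read-out higher numbers stand for higher permeability and lower numbers for lower permeability), so far. Compound 1 (`Cc1cnc(NC(=O)c2cc(Oc3cnc(C(=O)N(C)C)cn3)c3cc(C)oc3c2)cn1`) gives 22.3 10^-6 cm/s and compound 2 (`Cc1cnc(NC(=O)c2cc(Oc3ccc(C(=O)N(C)C)nc3)c3cc(C)oc3c2)cn1`) gives 28.5 10^-6 cm/s as its reading, and these two values lie within the scatter of each other. Compound 3 (`Cc1ccc(Oc2cc(C(=O)Nc3cnc(C)cn3)cc3oc(C)cc23)cc1`) gives only 0.3 10^-6 cm/s and so has the lowest of the three numbers, well beyond the scatter from both of the others.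

Compound 4 (`Cc1cnc(NC(=O)c2cc(Oc3ccc(S(C)(=O)=O)cc3)c3cc(C)oc3c2)cn1`) is built from compound 3 by one change: methylsulfonyl in place of methyl on an aromatic carbon, para to a large group (methylsulfonyl in place of methyl on an aromatic carbon). The same difference can be read as 4-methylphenyl to 4-(methylsulfonyl)phenyl.

Among the compounds with values here, no measured pair shows this swap alone, so the evidence is indirect. Compound 1 at 22.3 10^-6 cm/s and compound 2 at 28.5 10^-6 cm/s both carry another group on the shared core in place of the 4-methylphenyl of compound 3, and both read far higher. A large upward step is therefore expected, estimated as a 60-fold higher number from compound 3 to compound 4 (1.78 log units; beyond the scatter) and lying well beyond the scatter. Compound 4 is estimated at 18 10^-6 cm/s with an expected range from 6 10^-6 cm/s to 40 10^-6 cm/s as its likely span.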

Compound 4, apparent permeability: 7.6 10^-6 cm/s
Beside the measured number, compound 4's estimate is 2.4-fold (0.37 log units) above it; the range from low to high includes it.
By their numbers in this assay, from the lowest: compound 3; then compound 4; then compounds 1 and 2 (each within the scatter of the next).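

In this assay, within the data shown here, this pair gives the first direct look at this position: with the rest of the molecule the same, methylsulfonyl in place of methyl on an aromatic carbon, para to a large group, gives a 25-fold higher number from compound 3 to compound 4 (1.40 log units; beyond the scatter). The low reading of compound 3 is therefore not set by the shared core alone, since one change at this position is enough to move the number far beyond the scatter. Nothing shown here gives a reason for this rise, so it stands as an observed difference between two structures.

As far as these compounds go, it remains open whether the rise is particular to methylsulfonyl or would also appear with another group in the same place, such as a nitrile, a carboxylic acid or an amine. From the compounds shown here alone, it is also open whether the same swap would give a step of similar size on another core or at another place on the ring, as this single pair speaks only for the 4-methylphenyl to 4-(methylsulfonyl)phenyl change on the shared core.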